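A Benzyl Ether Swap Tested for Cell Toxicity

The source may hold more compounds than are shown below. What is called first, only, known or untested is meant among the compounds shown, and "the series" means these compounds.

Compound 3 `COc1ccc(COc2c(OC)c(OC)cc3c2C(=O)[C@]2(OC)C=C[C@H]3N(C(=O)OCC(C)C)N2C(=O)OCC(C)C)cc1` is measured in an ADME assay on KB cells (Homo sapiens) for cytotoxicity (a higher number here means that more compound is needed for the effect, a lower number that less compound is needed), where compound 3 gives 47.9 ug/mL. Among the two numbers on hand this is the lowest, yet its neighbour compound 1 `CCOC(=O)N1[C@@H]2C=C[C@@](OC)(C(=O)c3c2cc(OC)c(OC)c3OCc2ccc(OC)cc2)N1C(=O)OCC` gives 63.1 ug/mL in this assay, a gap that stays within the usual scatter, so the two cannot be ranked. Compound 2 `CCOC(=O)N1[C@@H]2C=C[C@@](OC)(C(=O)c3c2cc(OC)c(OC)c3OCC)N1C(=O)OCC` gives only a limit in this assay, > 300 ug/mL.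

Compound 4 `COc1cc2c(c(OCc3ccccc3F)c1OC)C(=O)[C@]1(OC)C=C[C@H]2N(C(=O)OCC(C)C)N1C(=O)OCC(C)C` is not yet measured. It differs from compound 3 in one place: 2-fluorophenyl in place of 4-methoxyphenyl on a saturated chain carbon bound to an oxygen on an aromatic ring.

Going by the values given here, one measured step touches the same place. There, an at least 4.7-fold higher number from compound 1 to compound 2 (0.67 log units; beyond the scatter), so that the value ended at the limit of > 300 ug/mL in this assay, at which 1 of the 3 values shown sits. That step removed the whole aromatic ring from the benzylic position; the present change keeps an aromatic ring there and only exchanges 4-methoxyphenyl for 2-fluorophenyl. The earlier step therefore points to the direction in which a loss at this position weakens the effect, but it does not tell how a retained ring of a different kind behaves.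

The expectation is a small step, a 1.4-fold higher number from compound 3 to compound 4 (0.13 log units; within the scatter), and compound 4 is estimated at 65 ug/mL, likely between 30 ug/mL and 150 ug/mL.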

Compound 4, concentration for half-maximal effect: 109 ug/mL
Estimate against measurement, compound 4: 1.7-fold (0.22 log units) below; the range from low to high includes it.
By their numbers in this assay, from the lowest: compounds 3, 1 and 4 (each within the scatter of the next, the first and the last beyond it). At a limit, above all of these: compound 2.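

The result shows that keeping an aromatic ring at this place does not by itself preserve the effect in this assay: 2-fluorophenyl in place of 4-methoxyphenyl gives a 2.3-fold higher number from compound 3 to compound 4 (0.36 log units; beyond the scatter), so more compound is needed after the swap. The earlier compounds shown here showed only what follows when the whole ring is replaced by methyl, whereas this modest step shows that exchanging one substituted ring for another also moves the number, and in the same direction. The methyl compound itself gives no exact number for comparison, as compound 2 stands at a limit of the assay: the limit of > 300 ug/mL in this assay, at which 1 of the 4 values shown sits.

This single swap removes a methoxy group and introduces a fluorine at a different ring position, so the compounds shown cannot separate the loss of the 4-methoxy group from the arrival of the 2-fluoro group. As far as these compounds go, whether a plain phenyl, a 4-fluorophenyl or a 2-methoxyphenyl would sit closer to compound 3 or to compound 4 stays open, as does the outcome for a ring carrying an amine or a carboxylic acid.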